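Oxime ether to free oxime in a mouse whole-animal assay

The source may report more compounds than this note shows. Statements on the series, on what has been measured and on what is new or still open speak of the compounds shown alone.

Measured so far:
Compound 1, `O=[N+]([O-])c1ccc(Cn2cc(CO/N=C/c3c(-c4ccc(F)cc4)nc4ccc(Br)cn34)nn2)cc1`, 40 mg/kg
Compound 2, `C#CCO/N=C/c1c(-c2ccc(C)cc2)nc2ccc(Br)cn12`, 20 mg/kg

The study rests on two measured compounds. In a functional assay on the whole organism (strain NMRI) with Mus musculus as the target, with a stated time of 0.5 h (on this read-out lower numbers stand for an effect already at smaller amounts and higher numbers for an effect only at larger amounts of compound), compound 1 gives 40 mg/kg, and in this assay compound 2 gives 20 mg/kg. The number for compound 2 is the nearer to the low end of the two, yet the gap to compound 1 lies within the usual scatter, so the two compounds cannot be set apart on what is shown, and no step between them is computed.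

The piece now follows the path from compound 2 to compound 3, `Cc1ccc(-c2nc3ccc(Br)cn3c2/C=N/O)cc1`, which has not yet been measured in this assay. The change is hydrogen in place of propargyl on an oxygen. Within the data shown here, no measured pair covers this change, so expectations rest on compound 2 alone. Compound 3 is expected to give a number somewhat higher than compound 2, a step of a 1.5-fold higher number from compound 2 to compound 3 (0.18 log units; within the scatter), though one that may not exceed the scatter. The estimate for compound 3 in this assay is 30 mg/kg, with a range from 10 mg/kg to 100 mg/kg.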

Compound 3, minimum effective dose: 20 mg/kg
Estimate against measurement, compound 3: 1.5-fold (0.18 log units) above; the measured number falls inside the stated range.
By their numbers in this assay, from the lowest: compounds 2, 3 and 1 (each within the scatter of the next).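

In this assay, hydrogen in place of propargyl on the oxygen gives no change at the digits printed from compound 2 to compound 3 (within the scatter), so on this evidence the propargyl group is not required for a reading at this dose level, and the free oxime of compound 3 cannot be told apart from the ether of compound 2. The earlier compounds shown here could not show this: compound 1 and compound 2 differ in more than one place, so neither this position nor this change could be read on its own until this pair was available. Nothing shown gives a reason for this result or tells what either group does in the animal.

This single pair leaves open whether a methyl, a longer chain such as butyl, or a benzyl group on the same oxygen would read the same way in this assay, since only the two ends of the change, propargyloxy and hydroxy, are covered. It also leaves open whether an amine or a carboxylic acid could stand in place of the whole oxime, and whether propargyloxy to hydroxy reads alike on the core of compound 1.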